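This account rests on a few compounds, and the source may have more. Where it says the series, first, only, none or still open, it means among the compounds named here.

Measured so far, in a functional assay (aorta) for antagonist activity, with Oryctolagus cuniculus as the target; a lower number here means a stronger inhibitor, a higher number a weaker inhibitor:
compound 1 `CCCCc1ccc(CNC(=O)Nc2ccccc2)c(=O)n1Cc1ccc(-c2ccccc2-c2nn[nH]n2)cc1` gives 30 nM
compound 2 `CCCCNC(=O)NCc1ccc(CCCC)n(Cc2ccc(-c3ccccc3-c3nn[nH]n3)cc2)c1=O` gives 10 nM
compound 3 `CCCCc1ccc(CN(Cc2ccccc2)C(C)=O)c(=O)n1Cc1ccc(-c2ccccc2-c2nn[nH]n2)cc1` gives 1 nM

Compound 3 has the lowest number of the three in this assay; compound 2 is nearest, with a 10-fold lower number from compound 2 to compound 3 (1.00 log units; beyond the scatter), and compound 1 is furthest, with a 30-fold lower number from compound 1 to compound 3 (1.48 log units; beyond the scatter). Compound 4 `CCCCc1ccc(CNS(=O)(=O)c2ccc(C)cc2)c(=O)n1Cc1ccc(-c2ccccc2-c2nn[nH]n2)cc1` differs from compound 3 in one place: ((4-methylphenyl)sulfonyl)amino in place of acetyl(benzyl)amino on a saturated chain carbon bound to an aromatic carbon.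

For the measured compounds named here, two measured steps bear on this. Both arrived at compound 3 by exchanging a (carbamoyl)amino group, which carries a hydrogen-bond donor, for acetyl(benzyl)amino, which carries none: a 30-fold lower number from compound 1 to compound 3 (1.48 log units; beyond the scatter) was large and a 10-fold lower number from compound 2 to compound 3 (1.00 log units; beyond the scatter) modest. The step from compound 3 to compound 4 runs in the opposite sense, putting back a group with one hydrogen-bond donor and removing the benzyl from the nitrogen. The third step, a 3.0-fold lower number from compound 1 to compound 2 (0.48 log units; beyond the scatter), shows that changing only the substituent on the amide-type nitrogen moved the number modestly. On this basis compound 4 is expected to give a higher number than compound 3 in this assay, roughly a 15-fold higher number from compound 3 to compound 4 (1.18 log units; beyond the scatter). The estimate for compound 4 is therefore 15 nM, with a range from 3 nM to 80 nM.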

Compound 4, half-maximal inhibitory concentration: 9 nM
The estimate for compound 4 lay 1.7-fold (0.22 log units) above the measured number; measured number inside the range.
By their numbers in this assay, from the lowest: compound 3; then compounds 4 and 2 (each within the scatter of the next); then compound 1.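

In this assay, a (4-methylphenyl)sulfonyl group on the amine nitrogen can stand in for a carbamoyl group at this position: in place of butylcarbamoyl it leaves the number unchanged (a 1.1-fold lower number from compound 2 to compound 4 (0.05 log units; within the scatter)), and in place of phenylcarbamoyl it improves it (a 3.3-fold lower number from compound 1 to compound 4 (0.52 log units; beyond the scatter)). Swapping acetyl(benzyl)amino for ((4-methylphenyl)sulfonyl)amino keeps the heavy-atom count and one six-membered aromatic ring, yet still costs potency (a 9.0-fold higher number from compound 3 to compound 4 (0.95 log units; beyond the scatter)), so matching those two features is not enough to retain the low number of compound 3. Among these four compounds, no exception appears to a simple pattern: compound 1, compound 2 and compound 4 all carry a hydrogen-bond donor in this group and all give higher numbers than compound 3, which carries none.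

Compound 4 both gains that donor and loses the benzyl, so the two changes cannot be separated, and a methyl on the sulfonamide nitrogen of compound 4 would be one way to pull them apart. Nothing measured here accounts for why the number moves with these changes at this position.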